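The compounds below may be only part of what the source reports. "The series", "measured", "known", "first", "only" and "open" are said of these compounds alone.

Working notes on a small set of chalcones sharing one core. Compound 1 `COc1cc(O)c(C(=O)/C=C/c2ccc(F)cc2)c(OC)c1` and compound 2 `COc1cc(OC)c(C(=O)/C=C/c2ccccc2OC)c(OC)c1` have both been run in a functional assay on PC-3 cells (Homo sapiens) for cytotoxicity, with a stated time of 48 h; a higher number here means a weaker inhibitor, a lower number a stronger inhibitor. In this assay compound 1 gives 13200 nM, and compound 2 gives 8100 nM. The two numbers sit within the scatter of each other, so nothing can be said about which of the pair is the stronger inhibitor; both are weak on this readout. For the measured compounds named here, no step between the two has been worked out, as they differ in more than one place.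

The next compound, compound 3 `COc1cc(OC)c(C(=O)/C=C/c2ccccc2SC)c(OC)c1`, differs from compound 2 in one place only: methylsulfanyl in place of methoxy on an aromatic carbon. This is a conservative exchange of one two-atom group for another of the same count and shape. Going by the values given here, with only two weak measured points and no single-change step on record, there is no basis to expect a large move in either direction. The step from compound 2 to compound 3 is expected to be small, a 1.4-fold lower number from compound 2 to compound 3 (0.13 log units; within the scatter), not clearly beyond the scatter. For compound 3 the half-maximal inhibitory concentration is estimated at 6000 nM, within a range of 2500 nM to 16000 nM.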

Compound 3, half-maximal inhibitory concentration: 7600 nM
Compound 3: the middle estimate sits 1.3-fold (0.10 log units) below what was measured, and the stated range covers the measured number.
By their numbers in this assay, from the lowest: compounds 3, 2 and 1 (each within the scatter of the next).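

For the compounds shown here, the exchange of methoxy for methylsulfanyl, on an aromatic carbon of a six-membered aromatic ring of carbon only and ortho to a large group, gives the first single-change step: a 1.1-fold lower number from compound 2 to compound 3 (0.03 log units; within the scatter) in this assay. On this evidence, the 2-methoxyphenyl and 2-(methylsulfanyl)phenyl forms cannot be told apart on this read-out, so this position accepts either group without a readable difference, at least with the rest of the structure of compound 2 held fixed. No supporting measurement bears on this result, and the step itself gives no account of how the two groups compare in any other respect.

The compounds shown leave open whether any group at this position can separate itself from the scatter, for instance an amine, a carboxylic acid or a longer chain such as a butoxy group. They also leave open whether the same methoxy to methylsulfanyl exchange would read the same at another place on this aromatic ring or on a core carrying the hydroxy group of compound 1.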